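A few compounds are considered here, and "the series" means these few. Any claim that something is new, unique, unknown or untested is made for them only; others in the source may bear on it.

Measured compounds:
compound 1 `O=C(CN1CCCCC1)Nc1ccc(-c2nc3cc(Cl)c(Cl)cc3[nH]2)cc1` — 45000 nM
compound 2 `CCC(=O)Nc1ccc(-c2nc3ccccc3[nH]2)cc1` — > 100000 nM

Both compounds were tested in an ADME assay on MDBK cells (Bos taurus) for cytotoxicity, read by MTT assay, with a stated time of 96 h; on this read-out higher numbers stand for lower toxicity in this test and lower numbers for higher toxicity in this test. Going by the values given here, compound 1 gives 45000 nM and is the only compound with a real number. Compound 2 gives > 100000 nM, which is a limit of the assay and not a number. So compound 1 stands as the one measured point, with the other value sitting at the limit of > 100000 nM in this assay, at which 1 of the 2 values shown sits.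

Compound 3 `CC(=O)Nc1ccc(-c2nc3cc(Cl)c(Cl)cc3[nH]2)cc1` has not yet been tested. It differs from compound 1 by hydrogen in place of piperidin-1-yl on a saturated chain carbon bound to a carbonyl carbon: the piperidin-1-yl group is gone and a hydrogen sits on the saturated chain carbon bound to the carbonyl carbon. Among the compounds with values here, no step between measured compounds exists to calibrate this change. Still, the step from compound 1 to compound 3 is expected to run upward in this assay, beyond the scatter, because one of the two values sits at the limit of > 100000 nM in this assay, at which 1 of the 2 values shown sits. Compound 3 is expected to give 85000 nM, within 30000 nM to 250000 nM, a change of a 1.9-fold higher number from compound 1 to compound 3 (0.28 log units; within the scatter).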

Compound 3, half-maximal cytotoxic concentration: 58000 nM
Compound 3: middle estimate off by 1.5-fold (0.17 log units), on the high side; the range from low to high includes it.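

Replacing the piperidin-1-yl group with hydrogen on the saturated chain carbon bound to a carbonyl carbon gives, in this assay, a 1.3-fold higher number from compound 1 to compound 3 (0.11 log units; within the scatter). Going by these compounds alone, this is the first step that can be read at this position, and it lies within the scatter, so the loss of this whole six-membered ring leaves compound 1 and compound 3 indistinguishable in this test. Compound 2 holds the only value that is a limit and not a number, and it differs from compound 3 in more than one place, so no step to it can be read: the limit of > 100000 nM in this assay, at which 1 of the 3 values shown sits.

From the compounds shown here alone, it remains open whether other groups on this carbon, such as a dimethylamino group, a carboxylic acid or a longer chain, would also stay within the scatter. Going by these compounds, it is also open whether the same replacement would give so small a step on the core of compound 2.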